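From decyl to tert-butyl on the shared core

The source may report more compounds than this note shows. Statements on the series, on what has been measured and on what is new or still open speak of the compounds shown alone.

In an ADME assay on HFF cells (Homo sapiens) for cytotoxicity, read by MTT assay, with a stated time of 72 h (on this read-out higher numbers stand for weaker inhibition and lower numbers for stronger inhibition), compound 1 `O=C1O[C@H]([C@@H](O)Cn2cc(-c3cccc(O)c3)nn2)C(OCc2ccccc2)=C1OCc1ccccc1` gives 39000 nM. Compound 2 `CCCCCc1ccc(-c2cn(C[C@H](O)[C@H]3OC(=O)C(OCc4ccccc4)=C3OCc3ccccc3)nn2)cc1` gives > 100000 nM, which is a limit of the assay. Compound 3 `CCCCCCCCCCc1cn(C[C@H](O)[C@H]2OC(=O)C(OCc3ccccc3)=C2OCc2ccccc2)nn1` gives > 100000 nM, again a limit. That places compound 3 at the limit of > 100000 nM in this assay, at which 2 of the 3 values shown sit. Compound 4 `CC(C)(C)c1cn(C[C@H](O)[C@H]2OC(=O)C(OCc3ccccc3)=C2OCc2ccccc2)nn1` has tert-butyl in place of decyl on an aromatic carbon. Putting 4-pentylphenyl in place of 3-hydroxyphenyl gave an at least 2.5-fold higher number from compound 1 to compound 2 (0.40 log units; beyond the scatter), and putting decyl in its place gave an at least 2.5-fold higher number from compound 1 to compound 3 (0.40 log units; beyond the scatter). Decyl in place of 4-pentylphenyl gave a step that the two limits leave unreadable from compound 2 to compound 3. None of these steps involves tert-butyl, so only a modest move toward lower numbers is expected. The expected change is an at least 1.2-fold lower number from compound 3 to compound 4 (0.09 log units; that floor lies within the scatter). For compound 4 the estimated value is 80000 nM, with an expected range from 30000 nM to 200000 nM.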

Compound 4, half-maximal inhibitory concentration: 13300 nM
Beside the measured number, compound 4's estimate is 6.0-fold (0.78 log units) above it, and the stated range ends above it.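

In this assay, the group on this aromatic carbon can move the number down as well as up: tert-butyl in place of decyl gave an at least 7.5-fold lower number from compound 3 to compound 4 (0.87 log units; beyond the scatter), and tert-butyl in place of 4-pentylphenyl gave an at least 7.5-fold lower number from compound 2 to compound 4 (0.87 log units; beyond the scatter). Tert-butyl in place of 3-hydroxyphenyl gave a 2.9-fold lower number from compound 1 to compound 4 (0.47 log units; beyond the scatter), so compound 4 shows the strongest inhibition of the four. The two larger steps are only floors, because compound 2 and compound 3 each stand at a limit: the limit of > 100000 nM in this assay, at which 2 of the 4 values shown sit.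

The compounds shown do not separate the length of the chain from its branching. Going by these compounds, a straight butyl chain at this position could test that, and where an amine there would land remains open.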